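This account rests on a few compounds, and the source may have more. Where it says the series, first, only, none or still open, it means among the compounds named here.

In an ADME assay (liver) for metabolic stability, with Liver microsome (Homo sapiens) as the target, read by LC-MS, using microsomes and NADPH, with a stated time of 5 min, at 37 degrees C (on this read-out higher numbers stand for fast clearance and lower numbers for slow clearance), compound 3 `CCCn1cc(S(=O)(=O)N[C@H](C)c2nc3ccc(C(F)(F)F)cc3n2CC)c(C)n1` gives > 100 mL.min-1.g-1, which is a limit of the assay and not a number. Compound 1 `CCn1c([C@@H](C)NS(=O)(=O)c2cccc(C#N)c2)nc2ccc(C(F)(F)F)cc21` gives > 100 mL.min-1.g-1, which is also a limit. Compound 2 `CCn1c([C@@H](C)NS(=O)(=O)c2cn(C)nc2C)nc2ccc(C(F)(F)F)cc21` gives a measured number, 28 mL.min-1.g-1. Compound 3, by contrast, stands at the limit rather than at a known value.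

Compound 4 `CCn1c([C@@H](C)NS(=O)(=O)c2cn(C)c(C)n2)nc2ccc(C(F)(F)F)cc21` keeps the shared core and changes only the group on the sulfonyl sulfur: a group of 7 heavy atoms (5 carbon, 2 nitrogen; one five-membered aromatic ring with 2 hetero atoms) in place of a group of 9 heavy atoms (7 carbon, 2 nitrogen; one five-membered aromatic ring with 2 hetero atoms), on a sulfonyl sulfur. The entering group is 1,2-dimethyl-1H-imidazol-4-yl.

Two measured steps offer guidance, and both lie beyond the usual scatter. One is an at least 3.5-fold higher number from compound 2 to compound 3 (0.55 log units; beyond the scatter), and the other is an at least 3.5-fold lower number from compound 1 to compound 2 (0.55 log units; beyond the scatter). A third, a step that the two limits leave unreadable from compound 1 to compound 3, offers no guidance on size. The group entering compound 4 resembles the group of compound 2 more closely than that of compound 3, so compound 2 at 28 mL.min-1.g-1 is the better guide. Among the compounds with values here, this resemblance is only a structural comparison, and no measured step tests the entering group directly.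

A fall of similar size is therefore expected, and the estimated step is an at least 3.5-fold lower number from compound 3 to compound 4 (0.55 log units; beyond the scatter). For compound 4 the estimated value is 28 mL.min-1.g-1, with an expected range of 11 mL.min-1.g-1 to 75 mL.min-1.g-1.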

Compound 4, intrinsic clearance in microsomes: 43 mL.min-1.g-1
Compound 4: middle estimate off by 1.5-fold (0.19 log units), on the low side; the measured number falls inside the stated range.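

In this assay, 1,2-dimethyl-1H-imidazol-4-yl on the sulfonyl sulfur brings clearance down from the limit, giving an at least 2.3-fold lower number from compound 3 to compound 4 (0.36 log units; beyond the scatter) and an at least 2.3-fold lower number from compound 1 to compound 4 (0.36 log units; beyond the scatter). Exchanging 1,3-dimethyl-1H-pyrazol-4-yl for this group gives a 1.5-fold higher number from compound 2 to compound 4 (0.19 log units; within the scatter), so the read-out does not separate the two, and a second dimethyl-substituted five-membered aromatic ring with 2 hetero atoms now behaves like the first, while compound 3, with a group of 9 heavy atoms of the same ring type, goes against any rule that the ring type alone is enough. The steps that start from compound 1 and compound 3 give only a minimum size, since each of those compounds carries a limit and not a number: the limit of > 100 mL.min-1.g-1 in this assay, at which 2 of the 4 values shown sit.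

From the compounds shown here alone, how much of the gap to compound 3 belongs to its propyl chain, and whether that longer chain on 1,2-dimethyl-1H-imidazol-4-yl would also reach the limit, stays open. So does what a saturated amine such as morpholine would give on the sulfonyl sulfur in place of these aromatic groups.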